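Bromo-to-fluoro swap on the N-aryl ring of compound 3

The source may hold more compounds than are shown below. What is called first, only, known or untested is meant among the compounds shown, and "the series" means these compounds.

Measured compounds:
- compound 1 `CC(=O)Oc1ccc(/C=C/C(=O)OCCSc2nc(-c3ccc(S(C)(=O)=O)cc3)n(-c3ccc(F)cc3)n2)cc1OC(C)=O` gives 1050 nM
- compound 2 `CC(=O)Oc1ccc(/C=C/C(=O)OCCSc2nc(-c3ccc(S(C)(=O)=O)cc3)n(-c3ccccc3)n2)cc1OC(C)=O` gives 1210 nM
- compound 3 `CC(=O)Oc1ccc(/C=C/C(=O)OCCSc2nc(-c3ccc(S(N)(=O)=O)cc3)n(-c3ccc(Br)cc3)n2)cc1OC(C)=O` gives 1050 nM

The values above come from an assay on cells (strain Sprague-Dawley) for inhibition of Polyunsaturated fatty acid 5-lipoxygenase (Rattus norvegicus), with a stated time of 30 min; on this read-out higher numbers stand for weaker inhibition and lower numbers for stronger inhibition. Compound 3 stands level with compound 1 at the digits printed, and the two together give the lowest numbers of the three; compound 2 sits a touch higher, with a 1.2-fold higher number from compound 1 to compound 2 (0.06 log units; within the scatter) showing that this gap is within the scatter. Going by the values given here, no pair among the three is separated beyond the scatter, so no order of potency can be read from them.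

Compound 4 `CC(=O)Oc1ccc(/C=C/C(=O)OCCSc2nc(-c3ccc(S(N)(=O)=O)cc3)n(-c3ccc(F)cc3)n2)cc1OC(C)=O` is the unmeasured partner of compound 3. The change is fluoro in place of bromo on an aromatic carbon, on an aromatic carbon of a six-membered aromatic ring of carbon only, para to a large group; cut one bond further out it reads 4-bromophenyl to 4-fluorophenyl. Among the compounds with values here, the only measured step touching this ring is the fluoro-to-hydrogen exchange between compound 1 and compound 2, which stayed within the scatter. Within the data shown here, no bromo-to-fluoro step has been measured, and the sulfonamide-bearing pair of compound 3 and compound 4 has no direct precedent, so the expectation rests on that one small step: no change beyond the scatter in this assay, with a 1.0-fold higher number from compound 3 to compound 4 (0.02 log units; within the scatter) expected to be flat. Compound 4 is therefore estimated at 1100 nM, within the range 550 nM to 2200 nM.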

Compound 4, half-maximal inhibitory concentration: 1060 nM
Compound 4: middle estimate off by 1.0-fold (0.02 log units), on the high side; low and high end bracket the measured number.
By their numbers in this assay, from the lowest: compounds 1, 3, 4 and 2 (each within the scatter of the next).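

In this assay, going by these compounds alone, the swap from 4-bromophenyl to 4-fluorophenyl gives a direct bromo-to-fluoro reading at this place (a 1.0-fold higher number from compound 3 to compound 4 (0.00 log units; within the scatter)), which the earlier compounds did not offer. With fluoro held fixed on that ring, amino in place of methyl on the sulfonyl sulfur also gets its first single-place reading (a 1.0-fold higher number from compound 1 to compound 4 (0.00 log units; within the scatter)), so bromo and fluoro, and amino and methyl on the sulfur, are not told apart in these pairs. No independent data accompany these numbers to explain either step.

From the compounds shown here alone, whether a methoxy, a trifluoromethyl or a carboxylic acid at this place of the ring would separate from the halogens remains open. So does whether a longer alkyl chain on the sulfonyl sulfur would depart from the amino and methyl compounds.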